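Swapping 4-nitrophenyl for pyridin-4-yl on a shared core

The compounds below may be only part of what the source reports. "The series", "measured", "known", "first", "only" and "open" are said of these compounds alone.

Of the compounds shown here, two sharing one core have been measured so far. In a functional assay on MKN-45 cells (Homo sapiens) for inhibition, with a stated time of 72 h (on this read-out higher numbers stand for weaker inhibition and lower numbers for stronger inhibition), compound 1 `COc1ccc(S(=O)(=O)N2CCc3cccc(-c4ccco4)c32)cc1` gives 42 nM, and compound 2 `COc1ccc(S(=O)(=O)N2CCc3cccc(-c4ccc([N+](=O)[O-])cc4)c32)cc1` gives 34 nM. These two values lie within the scatter of each other, so compound 2 stands level with compound 1 on the numbers available.

Compound 3 `COc1ccc(S(=O)(=O)N2CCc3cccc(-c4ccncc4)c32)cc1` has not yet been measured. It differs from compound 2 by pyridin-4-yl in place of 4-nitrophenyl on an aromatic carbon, with pyridin-4-yl in place of 4-nitrophenyl on an aromatic carbon.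

Within the data shown here, one measured step bears on this change, the exchange of furan-2-yl for 4-nitrophenyl on an aromatic carbon. That step is a 1.2-fold lower number from compound 1 to compound 2 (0.09 log units; within the scatter), so two quite different groups there leave the read-out within the scatter. Among the measured compounds shown here, no measured compound carries pyridin-4-yl, however, and only two values are at hand.

No change beyond the scatter is therefore expected in this assay, and the expected step is a 1.2-fold higher number from compound 2 to compound 3 (0.07 log units; within the scatter). For compound 3 the estimated value is 40 nM, with a wide expected range from 15 nM to 120 nM.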

Compound 3, half-maximal inhibitory concentration: 69.5 nM
Estimate against measurement, compound 3: 1.7-fold (0.24 log units) below; low and high end bracket the measured number.
By their numbers in this assay, from the lowest: compounds 2, 1 and 3 (each within the scatter of the next, the first and the last beyond it).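

In this assay, among these compounds, pyridin-4-yl in place of 4-nitrophenyl on an aromatic carbon gives a 2.0-fold higher number from compound 2 to compound 3 (0.31 log units; beyond the scatter), the first step at this position to pass beyond the scatter, so the position is not wholly indifferent to the group it carries. The same entering group in place of furan-2-yl gives a 1.7-fold higher number from compound 1 to compound 3 (0.22 log units; within the scatter), so compound 1 cannot be told apart from compound 3, just as it could not be told apart from compound 2, and only the two ends of the series separate. Nothing measured here gives a cause for the step from 4-nitrophenyl to pyridin-4-yl.

The compounds shown leave open whether that step goes with the loss of the nitro group or with the entry of the ring nitrogen, a question that a plain phenyl group at this position would address directly. They also leave open how the read-out would respond to an amine or a carboxylic acid on that ring, or to a non-aromatic group such as morpholine in its place.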